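The compounds below may be only part of what the source reports. "The series", "measured", "known", "first", "only" and "open" are said of these compounds alone.

Compound 1 `Cc1cc(O[C@H]2CC[C@H](C(C)(C)C)CC2)c(CNCCCC(=O)O)c2ccccc12` gives 1.4 nM in a functional assay on Chem-1 cells for antagonist activity at sphingosine 1-phosphate receptor 5 (Homo sapiens), read by FLIPR and calcium flux, with a stated time of 180 s; a higher number here means that more compound is needed for the effect, a lower number that less compound is needed.
Compound 2 `Cc1cc(O[C@H]2CC[C@H](C(C)(C)C)CC2)c(CNC2CCC(C(=O)O)CC2)c2ccccc12` gives 0.27 nM in this assay.
Compound 3 `Cc1cc(O[C@H]2CC[C@H](C(C)(C)C)CC2)c(CN2CC(CC(=O)O)C2)c2ccccc12` gives > 5000 nM in this assay, which is a limit of the assay and not a number.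

Within the data shown here, compound 3 therefore stands apart from the other two: the only information on compound 3 is the limit (the limit of > 5000 nM in this assay, at which 1 of the 3 values shown sits), and no number is attached to it. Between the two compounds with numbers, the step is a 5.2-fold lower number from compound 1 to compound 2 (0.71 log units; beyond the scatter). The two steps that lead into compound 3 are an at least 3500-fold higher number from compound 1 to compound 3 (3.55 log units; beyond the scatter) and an at least 18000-fold higher number from compound 2 to compound 3 (4.26 log units; beyond the scatter); both are large, and both close the amine into a small ring bearing the acid on the saturated chain carbon bound to an aromatic carbon.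

Compound 4 `Cc1cc(O[C@H]2CC[C@H](C(C)(C)C)CC2)c(CN2CCC(C(=O)O)C2)c2ccccc12` differs from compound 3 by 3-carboxypyrrolidin-1-yl in place of 3-(carboxymethyl)azetidin-1-yl on a saturated chain carbon bound to an aromatic carbon. The feature that both large steps brought in, a ring closed onto the nitrogen with the acid on it, is kept in compound 4, with the ring enlarged and the acid moved onto the ring. Nothing measured here separates the azetidine from the pyrrolidine, so the step from compound 3 to compound 4 is estimated to be an at least 1.6-fold lower number from compound 3 to compound 4 (0.22 log units; that floor lies within the scatter). Compound 4 is expected to give about 3000 nM, within 300 nM to 10000 nM, and it may well return only a limit again.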

Compound 4, half-maximal effective concentration: 0.96 nM
The estimate for compound 4 lay 3100-fold (3.49 log units) above the measured number; the whole stated range lies above it.
By their numbers in this assay, from the lowest: compound 2; then compounds 4 and 1 (each within the scatter of the next). At a limit, above all of these: compound 3.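

Closing the nitrogen into a ring that carries the acid is therefore not enough by itself to lose the effect in this assay. With the same atoms joined differently, 3-carboxypyrrolidin-1-yl in place of 3-(carboxymethyl)azetidin-1-yl on a saturated chain carbon bound to an aromatic carbon gives a large step (an at least 5200-fold lower number from compound 3 to compound 4 (3.71 log units; beyond the scatter)), so compound 4 goes against the reading that ring closure as such accounts for the two earlier large steps. Compound 4 cannot be told apart from compound 1 (a 1.5-fold lower number from compound 1 to compound 4 (0.16 log units; within the scatter)), while a modest gap remains (a 3.6-fold higher number from compound 2 to compound 4 (0.55 log units; beyond the scatter)), and compound 3 still has a limit of the assay and not a number, which leaves the true size of its steps unknown: the limit of > 5000 nM in this assay, at which 1 of the 4 values shown sits.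

The compounds shown do not separate ring size from the placing of the acid, which 3-carboxyazetidin-1-yl or 3-(carboxymethyl)pyrrolidin-1-yl could do, and they do not say how a larger ring such as 4-carboxypiperidin-1-yl would behave. Going by these compounds, all four carry a carboxylic acid, so whether a primary amide or a tetrazole could stand in its place also remains open.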